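Lengthening a Chlorinated Chain on a Shared Core

This account rests on a few compounds, and the source may have more. Where it says the series, first, only, none or still open, it means among the compounds named here.

Of the compounds shown here, three built on one shared core have been measured in a functional assay on HCT-116 cells (Homo sapiens) for inhibition, read by MTT assay, with a stated time of 48 h; on this read-out lower numbers stand for stronger inhibition and higher numbers for weaker inhibition. Compound 1 `C/C=C/C=C/C(=O)N(Cc1ccc(OC)c(O)c1)c1cc(OC)c(OC)c(OC)c1` gives 180 nM, compound 2 `COc1ccc(CN(C(=O)CO)c2cc(OC)c(OC)c(OC)c2)cc1O` gives 520 nM, and compound 3 `COc1ccc(CN(C(=O)CCl)c2cc(OC)c(OC)c(OC)c2)cc1O` gives 250 nM. The number for compound 3 cannot be told apart from that of compound 1, and only compound 2 stands clearly higher.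

Compound 4 `COc1ccc(CN(C(=O)CCCCCl)c2cc(OC)c(OC)c(OC)c2)cc1O` has not yet been measured. It keeps the core and differs in one place: 3-chloropropyl in place of chloro on a saturated chain carbon bound to a carbonyl carbon. Put another way, chloromethyl on the carbonyl carbon becomes 4-chlorobutyl.

Going by the values given here, no measured pair lengthens a chlorinated chain, so the evidence is indirect. Among the compounds with values here, the steps that bear on this change are all small. Replacing penta-1,3-dien-1-yl with chloromethyl gave a 1.4-fold higher number from compound 1 to compound 3 (0.14 log units; within the scatter), and replacing it with hydroxymethyl gave a 2.9-fold higher number from compound 1 to compound 2 (0.46 log units; beyond the scatter). Keeping a chlorine on the chain while exchanging hydroxy for chloro gave a 2.1-fold lower number from compound 2 to compound 3 (0.32 log units; beyond the scatter). Even very different groups on this carbonyl carbon have therefore moved the number only modestly.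

In this assay the estimated step is a 1.2-fold higher number from compound 3 to compound 4 (0.08 log units; within the scatter), so no change beyond the scatter is expected. The estimate for compound 4 is 300 nM, with an expected range of 130 nM to 700 nM.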

Compound 4, half-maximal inhibitory concentration: 220 nM
The estimate for compound 4 lay 1.4-fold (0.13 log units) above the measured number; the range from low to high includes it.
By their numbers in this assay, from the lowest: compounds 1, 4 and 3 (each within the scatter of the next); then compound 2.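

In this assay, the first direct test of chain length on this carbonyl carbon gives a 1.1-fold lower number from compound 3 to compound 4 (0.06 log units; within the scatter) when chloromethyl becomes 4-chlorobutyl, so the longer chlorinated chain is tolerated, with no change that can be told from the scatter. Compound 4 also cannot be told apart from the compound with the penta-1,3-dien-1-yl group (a 1.2-fold higher number from compound 1 to compound 4 (0.09 log units; within the scatter)), yet it stands clearly apart from the compound with the hydroxymethyl group (a 2.4-fold lower number from compound 2 to compound 4 (0.37 log units; beyond the scatter)), so the short and long chlorinated chains both give lower numbers than hydroxymethyl, while compound 1 shows that a group without chlorine can do the same. No measurement shown here accounts for why lengthening the chain made so little difference.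

The compounds shown leave open whether the number would hold for a longer chain still, or for a chain of this length ending in an amine or a carboxylic acid in place of the chlorine. They also leave open what the chlorine contributes to 4-chlorobutyl, a question that a plain butyl chain on the same carbonyl carbon would address.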